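Hydroxymethyl to fluoromethyl on the shared core

A few compounds are considered here, and "the series" means these few. Any claim that something is new, unique, unknown or untested is made for them only; others in the source may bear on it.

Three compounds on the shared core have a reading so far in an ADME assay, for this series. Compound 1 (`Cc1cc(=O)[nH]c(=O)n1C1O[C@H](C)[C@@H](O)[C@H]1O`) gives 9.5 in this measurement and compound 3 (`O=c1cc(CO)n(C2O[C@H](CO)[C@@H](O)[C@H]2O)c(=O)[nH]1`) gives 9.8 in it, two values within the scatter of each other. Compound 2 (`Cc1c(F)c(=O)[nH]c(=O)n1C1O[C@H](CO)[C@@H](O)[C@H]1O`) gives 7.7 as its reading, clearly lower than compound 3 and beyond the scatter. Compound 3 therefore shares the top of this small set with compound 1. Within the data shown here, no two measured compounds differ in one place only, so no measured step is available to carry over.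

The next compound is compound 4 (`O=c1cc(CF)n(C2O[C@H](CO)[C@@H](O)[C@H]2O)c(=O)[nH]1`), taken from compound 3. The change is fluoro in place of hydroxy on a saturated chain carbon bound to an aromatic carbon and amounts to fluoro in place of hydroxy on a saturated chain carbon bound to an aromatic carbon. Among the measured compounds shown here, the only measured compound with a fluoro is compound 2 (7.7), the lowest reading, but its fluoro is not on a saturated chain carbon and it differs from compound 3 in more than one place. That is weak guidance, and it supports only a modest expected fall. The expected move is a number 0.60 log units lower from compound 3 to compound 4 (beyond the scatter) and may barely clear the scatter. For compound 4 the estimated value is 9.2 with an expected range from 8.7 to 9.7 in this assay terms.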

Compound 4, acid dissociation constant: 9.8
For compound 4 the middle estimate is 0.60 log units below the measured one; measured number outside the range, above it.
By their numbers in this assay, from the lowest: compound 2; then compounds 1, 3 and 4 (each within the scatter of the next).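

In this assay, the change from hydroxymethyl to fluoromethyl gives no change at the digits printed from compound 3 to compound 4 (within the scatter). Among these compounds, this is the first step between two compounds that differ in one place, so the reading at a saturated chain carbon bound to an aromatic carbon can now be followed for a single change: the hydroxy leaves with its hydrogen-bond donor and acceptor, the fluoro enters with neither, and this read-out stays within the scatter. No available data bear on why the reading holds at this place.

Among the compounds shown here, this single step covers only one exchange at one place, so it does not show whether the reading stays within the scatter for other groups on the same chain carbon, such as an amine, a carboxylic acid or a longer chain like hydroxyethyl. Nor does it show whether fluoro in place of hydroxy would give the same result on a different core or at another place on the shared core.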